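Cytotoxicity Holds Steady Across a Thiazole Swap

The source may report more compounds than this note shows. Statements on the series, on what has been measured and on what is new or still open speak of the compounds shown alone.

Compound 1 `COc1ccc2c(O[C@H]3C[C@H]4C(=O)N(C)CCCC/C=C/[C@@H]5C[C@@]5(C(=O)NS(=O)(=O)C5(C)CC5)NC(=O)N4C3)cc(-c3nc(C(F)(F)F)cs3)nc2c1C` and compound 2 `COc1ccc2c(O[C@H]3C[C@H]4C(=O)N(C)CCCC/C=C/[C@@H]5C[C@@]5(C(=O)NS(=O)(=O)C5(C)CC5)NC(=O)N4C3)cc(-c3nc(C4CCC4)cs3)nc2c1Cl` share the same core and differ only on the aromatic five-membered ring and the neighbouring ring. In an ADME assay on Huh-7 cells (Homo sapiens) for cytotoxicity, read by colorimetric assay (a higher number here means that more compound is tolerated, a lower number that less compound is tolerated), compound 1 gives 75000 nM, and compound 2 gives 75000 nM, so compound 2 stands level with compound 1 within the scatter. Compound 3 `COc1ccc2c(O[C@H]3C[C@H]4C(=O)N(C)CCCC/C=C/[C@@H]5C[C@@]5(C(=O)NS(=O)(=O)C5(C)CC5)NC(=O)N4C3)cc(-c3nc(C#N)cs3)nc2c1Cl` differs from compound 2 by cyano in place of cyclobutyl on an aromatic carbon. For the measured compounds named here, no measured pair shows this change, so no step can be read from the data. The step of a 1.1-fold lower number from compound 2 to compound 3 (0.03 log units; within the scatter) is expected to be none beyond the scatter. Compound 3 is estimated at 70000 nM, in a range from 30000 nM to 100000 nM.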

Compound 3, half-maximal cytotoxic concentration: 75000 nM
Estimate against measurement, compound 3: 1.1-fold (0.03 log units) below; measured number inside the range.
By their numbers in this assay, from the lowest: compounds 1, 2 and 3 (each within the scatter of the next).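

In this assay, replacing cyclobutyl with cyano on the aromatic carbon next to the ring nitrogen gives no change at the digits printed from compound 2 to compound 3 (within the scatter). For the compounds shown here, this is the first reading of a change at this position alone, since compound 1 and compound 2 differ in two places. Here, the 4-cyclobutyl-1,3-thiazol-2-yl to 4-cyano-1,3-thiazol-2-yl exchange leaves the tolerated concentration level. Nothing available explains this result. On these data alone, what an amine or a carboxylic acid on this carbon would give remains open, as does the separate contribution of each place in which compound 1 and compound 2 differ.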